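The source may report more compounds than this note shows. Statements on the series, on what has been measured and on what is new or still open speak of the compounds shown alone.

Measured in a functional assay on MCF7 cells (Homo sapiens) for cytotoxicity, read by MTT assay, with a stated time of 72 h; on this read-out higher numbers stand for weaker inhibition and lower numbers for stronger inhibition:
Compound 1 `COc1cccc(/C=C2\CCC/C(=C\c3cccc(Cl)c3Cl)C2=O)c1OC`: > 20000 nM
Compound 2 `COc1cc(/C=C2\CCC/C(=C\c3cccc(OC)c3OC)C2=O)cc(OC)c1`: 1700 nM
Compound 3 `COc1ccc(/C=C2\CCC/C(=C\c3cccc(Br)c3)C2=O)cc1OC`: 5300 nM

The entry for compound 1 is a limit of the assay and not a number. That leaves two actual numbers to compare. Compound 3, at 5300 nM, has the higher of them, and compound 2, at 1700 nM, lies lower by more than the usual scatter.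

The next compound to be tested in this assay is compound 4 `COc1ccc(/C=C2\CCC/C(=C\c3cccc(O)c3)C2=O)cc1OC`. It carries hydroxy in place of bromo on an aromatic carbon, meta to a large group, turning 3-bromophenyl into 3-hydroxyphenyl: hydroxy in place of bromo on an aromatic carbon. For the measured compounds named here, no pair of measured compounds differs in one place only, so nothing here shows directly what such a swap does, and the expectation stays broad. It rests on the numbers of compound 2, at 1700 nM, and compound 3, at 5300 nM, which lie fairly close together although the two compounds differ in several places. Going by the values given here, no large step is therefore expected. The estimated step, a 1.5-fold lower number from compound 3 to compound 4 (0.18 log units; within the scatter), stays within the scatter and leans slightly towards stronger inhibition. For compound 4 the estimate is 3500 nM, with an expected range from 900 nM to 14000 nM.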

Compound 4, half-maximal inhibitory concentration: 2900 nM
Compound 4: middle estimate off by 1.2-fold (0.08 log units), on the high side, and the stated range covers the measured number.
By their numbers in this assay, from the lowest: compounds 2, 4 and 3 (each within the scatter of the next, the first and the last beyond it). At a limit, above all of these: compound 1.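

For the compounds shown here, the pair of compound 3 and compound 4 is the first here to differ in one place only, so it gives the first direct reading of a single swap on the shared core: in this assay, hydroxy in place of bromo gives a 1.8-fold lower number from compound 3 to compound 4 (0.26 log units; within the scatter). This position, on an aromatic carbon and meta to a large group, therefore takes a hydrogen-bond donor and a hydrogen-bond acceptor that bromo lacks, while the 3-bromophenyl and 3-hydroxyphenyl compounds remain within the scatter of each other and cannot be put in order. Nothing measured in this set gives a reason for this outcome.

What the compounds shown leave open is how this position responds to an amine, a carboxylic acid or a longer chain such as propoxy, since a single step says nothing about groups of another kind. Going by these compounds alone, it is also open whether the same swap gives a similar step when the rest of the shared core is substituted differently, as no second pair carries it.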